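Acetyl in Place of Dimethylamino: Expected Cytotoxicity Read-out

The compounds below may be only part of what the source reports. "The series", "measured", "known", "first", "only" and "open" are said of these compounds alone.

Three compounds have been measured in a functional assay on HOP-62 cells (Homo sapiens) for cytotoxicity, read by sulforhodamine B assay, with a stated time of 48 h, tested at 0.01 uM; on this read-out lower numbers stand for a stronger effect and higher numbers for a weaker effect at the one concentration tested:

Compound 1 `COc1cc(C)cc(-c2c(-c3ccnc(-c4ccc(N(C)C)cc4)c3)cnn2CC#N)c1` gives 62%
Compound 2 `COc1cc(C)cc(-c2nn(CC#N)cc2-c2ccnc(-c3ccc(N(C)C)cc3)c2)c1` gives 99%
Compound 3 `Cc1cc(O)cc(-c2nn(CC#N)cc2-c2ccnc(-c3ccc(Oc4ccccc4)cc3)c2)c1` gives 108%

Of these three, compound 1 shows the lowest number, which on this read-out means the strongest effect at the single concentration tested. Compound 2 lies well above it, beyond the usual scatter, and compound 3 lies further above still. For the measured compounds named here, compound 2 and compound 3 differ from compound 1 in several places at once, so no single structural step between measured compounds can be read off here.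

Compound 4 `COc1cc(C)cc(-c2c(-c3ccnc(-c4ccc(C(C)=O)cc4)c3)cnn2CC#N)c1` has not been measured. It differs from compound 1 in one place: acetyl in place of dimethylamino on an aromatic carbon. Whether this exchange moves the read-out is not known from the measured compounds, since none of them carries the acetyl group. Going by the values given here, the only guide is that compound 1, with the dimethylamino group, stands apart from the other two, so losing that group may cost some of its effect. The step from compound 1 to compound 4 is therefore expected to be a number 23 percentage points higher from compound 1 to compound 4 (beyond the scatter), toward a weaker effect, though it could also stay within the scatter. For compound 4 the estimate in this assay is 85%, with a range from 55% to 110%.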

Compound 4, a percentage reported as activity, at one concentration (the size of the read-out at that concentration, not a potency): 81%
Compound 4: the middle estimate sits 4 percentage points above what was measured, and the stated range covers the measured number.
By their numbers in this assay, from the lowest: compound 1; then compound 4; then compounds 2 and 3 (each within the scatter of the next).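

In this assay, for the compounds shown here, acetyl in place of dimethylamino gives a number 19 percentage points higher from compound 1 to compound 4 (beyond the scatter), the first comparison here in which only one place changes, and it shows that the group at this position on the aromatic carbon matters to the read-out. The step is modest, yet it lies beyond the usual scatter, so dimethylamino and acetyl are not interchangeable here, even though each has 3 heavy atoms, no ring, 0 hydrogen-bond donors, 1 hydrogen-bond acceptor and no net charge. What differs in the counted features is that acetyl holds oxygen where dimethylamino holds nitrogen and brings a double bond outside the aromatic rings, but nothing shown explains why the read-out moves with this exchange.

The compounds shown leave open how other groups at this position would read, such as a primary amine, a methoxy group or a carboxylic acid, and so whether dimethylamino itself or simply the absence of acetyl sets the difference. They also leave open whether the same exchange would have a similar effect on the core of compound 2.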